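A few compounds are considered here, and "the series" means these few. Any claim that something is new, unique, unknown or untested is made for them only; others in the source may bear on it.

Measured so far:
- compound 1 `Cc1ccc([C@@H]2CC(=O)c3ccc(F)cc3O2)cc1`: in an in vitro assay on BTI-TN-5B1-4 cells for inhibition of Amine oxidase [flavin-containing] B (Homo sapiens) (on this read-out lower numbers stand for stronger inhibition and higher numbers for weaker inhibition), compound 1 gives 150 nM
- compound 2 `COc1ccc(C2CC(=O)c3ccc(C)cc3O2)cc1`: in this assay compound 2 gives 3350 nM
- compound 3 `COc1ccc2c(c1)OC(c1ccc(C)cc1)CC2=O`: in this assay compound 3 gives 550 nM

Compound 1 has the lowest number of the three in this assay. The nearest is compound 3, whose number is higher by a gap beyond the scatter, and the furthest is compound 2, whose number is higher by a wider gap, also beyond the scatter. No pair of these compounds differs in only one place, so no single step is available as a guide.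

Compound 4 `Cc1ccc([C@H]2CC(=O)c3ccc(F)cc3O2)cc1` is the next compound to be measured in this assay. It differs from compound 1 as follows: the two compounds have the same atoms and bonds and differ only in configuration as drawn: 1 of 1 stereo elements differ; a stereocentre at a saturated ring carbon is drawn S in compound 1 and R in compound 4

For the measured compounds named here, no measured pair in this set differs only in configuration, so the size of the step cannot be read off from the data. A change of configuration at the single stereocentre may well move the number, and the expectation is that it moves upward, beyond the scatter, giving a step of a 10-fold higher number from compound 1 to compound 4 (1.00 log units; beyond the scatter) from the value of compound 1. For compound 4 the estimate in this assay is 1500 nM, with a range from 300 nM to 7500 nM.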

Compound 4, half-maximal inhibitory concentration: 150 nM
Beside the measured number, compound 4's estimate is 10-fold (1.00 log units) above it; the measured number lies below the stated range.
By their numbers in this assay, from the lowest: compounds 1 and 4 (each within the scatter of the next); then compound 3; then compound 2.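

In this assay, for the compounds shown here, inverting the stereocentre at the saturated ring carbon gives no change at the digits printed from compound 1 to compound 4 (within the scatter), the first step that changes one place only. With this fluorine and this methyl on the core, the forms drawn S and R cannot be told apart on this read-out, so configuration at this carbon carries no measurable weight for this pair. The reading rests on a clean comparison, since nothing else changes: the fact that compounds 1 and 4 differ only in the configuration as drawn

Going by these compounds alone, whether this holds for other substituents stays open, as compounds 2 and 3 are drawn without configuration and no step links either to compound 1. An amine or a carboxylic acid in place of the fluorine, or a longer chain in place of the methyl, would test whether configuration at this carbon stays without effect.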